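Removing a methyl group and cytotoxicity in rat muscle cells

A few compounds are considered here, and "the series" means these few. Any claim that something is new, unique, unknown or untested is made for them only; others in the source may bear on it.

Measured compounds:
compound 1 `COc1cc(C2=NCCN2)ccc1-c1cc2cc(C3=NCCN3)ccc2o1` 7400 nM
compound 2 `COc1ccc(C2=NCCN2)cc1-c1cc2cc(C3=NCCN3)ccc2o1` 30800 nM
compound 3 `Oc1cc(C2=NCCN2)ccc1-c1cc2cc(C3=NCCN3)ccc2o1` 150000 nM

In an ADME assay on L6 cells (Rattus norvegicus) for cytotoxicity (on this read-out lower numbers stand for stronger inhibition and higher numbers for weaker inhibition), compound 1 gives 7400 nM, compound 2 gives 30800 nM and compound 3 gives 150000 nM. Compounds 1 and 2 carry the same atoms joined in a different arrangement; the difference between the two cores is not broken down here, and their values stand apart beyond the scatter.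

Compound 3 arises from compound 1 by one change hydrogen in place of methyl on an oxygen on an aromatic ring and this change gives a 20-fold higher number from compound 1 to compound 3 (1.31 log units; beyond the scatter).

Compound 4 `Oc1ccc(C2=NCCN2)cc1-c1cc2cc(C3=NCCN3)ccc2o1` has not yet been measured in this assay. It arises from compound 2 by the change (hydrogen in place of methyl on an oxygen on an aromatic ring), the same change as from compound 1 to compound 3, at the same kind of place. Because the step of a 20-fold higher number from compound 1 to compound 3 (1.31 log units; beyond the scatter) was large, compound 4 is expected to give a weaker result than compound 2, with an estimated step of a 15-fold higher number from compound 2 to compound 4 (1.16 log units; beyond the scatter). The estimate for compound 4 is 450000 nM, expected to lie between 120000 nM and 1500000 nM, resting on a single earlier example of this change.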

Compound 4, half-maximal inhibitory concentration: > 199000 nM
Compound 4 gave a limit, no number; the forecaster's own chance of this, stated with the estimate: 35%; the middle value lies beyond the limit too.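

In this assay compound 4 gives > 199000 nM, which is a limit of the assay and not a number. Replacing methoxy with hydroxy raises the number on the second core as well, giving an at least 6.4-fold higher number from compound 2 to compound 4 (0.81 log units; beyond the scatter), so on both cores shown the hydroxy compound is the weaker inhibitor of these cells, and the direction of the change carries over from one core to the other. The size of the change is another matter, since a limit gives only a floor for the new step, and whether the two cores respond equally strongly cannot be read: the same change on two cores in this assay, a 20-fold higher number (1.31 log units; beyond the scatter) from compound 1 to compound 3 and an at least 6.4-fold higher number (0.81 log units; beyond the scatter) from compound 2 to compound 4; the limit leaves it open whether they differ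

Two pairs are too few to make a rule for the whole series, and the compounds shown leave open whether the same direction would hold on any further core. They also leave open what a longer chain on that oxygen, or an amine in place of the hydroxy group, would give in this assay.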